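This account rests on a few compounds, and the source may have more. Where it says the series, first, only, none or still open, it means among the compounds named here.

Series notes. Compound 1 `CN1Cc2c(N)cccc2C(c2ccc(Cl)cc2)C1` gives 1.5 mg/kg in a functional assay on the whole organism for inhibition of sodium-dependent dopamine transporter (Mus musculus); a higher number here means that more compound is needed for the effect, a lower number that less compound is needed. Compound 2 `CCNC(=O)Nc1cccc2c1CN(C)CC2c1ccccc1` reaches only the limit of this assay, > 80 mg/kg. Compound 3 `CCCCNC(=O)Nc1cccc2c1CN(C)CC2c1ccccc1` gives 69 mg/kg in this assay. Of the two numbers in hand, compound 3 stands highest, with compound 1 as its nearest neighbour at a much lower number. Within the data shown here, the one step measured inside the series, an at least 1.1-fold lower number from compound 2 to compound 3 (0.06 log units; that floor lies within the scatter), concerns the chain on the urea and lies within the scatter. The limit of > 80 mg/kg in this assay, at which 1 of the 3 values shown sits, applies to compound 2 and caps what that step can show. Compound 4 `CCCCNC(=O)Nc1cccc2c1CN(C)CC2c1ccc(Cl)cc1` differs from compound 3 by chloro in place of hydrogen on an aromatic carbon. Among the measured compounds shown here, no measured step isolates this change: compound 1 carries the same chloro but differs from compound 3 in another place as well, so the values of compound 1 and compound 3 show only that the chloro-bearing member sits far lower. A moderate fall in this assay is expected for compound 4, a 2.3-fold lower number from compound 3 to compound 4 (0.36 log units; beyond the scatter). Compound 4 is estimated at 30 mg/kg, range 8 mg/kg to 80 mg/kg.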

Compound 4, dose for half-maximal effect: about 120 mg/kg
Compound 4: middle estimate off by 4.0-fold (0.60 log units), on the low side; the whole stated range lies below it.
By their numbers in this assay, from the lowest: compound 1; then compounds 3 and 4 (each within the scatter of the next).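

Chloro in place of hydrogen, on the aromatic carbon para to a large group, leaves the read-out in this assay within the scatter: a 1.7-fold higher number from compound 3 to compound 4 (0.24 log units; within the scatter). The far lower number of compound 1 therefore cannot be credited to the chloro, which compound 4 carries as well. With the chloro held constant, the large gap goes with the other place, butylcarbamoyl in place of hydrogen on the aromatic nitrogen: an 80-fold higher number from compound 1 to compound 4 (1.90 log units; beyond the scatter).

Going by these compounds, whether a smaller group on that nitrogen, such as acetyl or methyl, stays near compound 1 or moves towards compound 4 remains open, as does whether fluoro or methoxy in place of the chloro would behave alike. How far the chain on the urea matters also stays unresolved, since the value of compound 2 is only a limit: the limit of > 80 mg/kg in this assay, at which 1 of the 4 values shown sits.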